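Adding an ethoxy group to the dichlorophenyl ring

The compounds below may be only part of what the source reports. "The series", "measured", "known", "first", "only" and "open" are said of these compounds alone.

Measured so far in an in vitro assay on Sf9 cells for displacement of a labelled ligand from Neuropeptide Y receptor type 1 (Homo sapiens); on this read-out higher numbers stand for weaker inhibition and lower numbers for stronger inhibition:
compound 1 `Cc1cc(NCCNC2CCCC2)n2nc(C)c(-c3c(Cl)cccc3Cl)c2n1` gives 38 nM
compound 2 `Cc1cc(NCCNC2CCOCC2)n2nc(C)c(-c3c(Cl)cccc3Cl)c2n1` gives 7 nM

Going by the values given here, compound 2 stands at the lower of the two numbers; the only measured step is a 5.4-fold lower number from compound 1 to compound 2 (0.73 log units; beyond the scatter), a change on the amine nitrogen. Compound 3 `CCOc1cc(Cl)c(-c2c(C)nn3c(NCCNC4CCOCC4)cc(C)nc23)c(Cl)c1` differs from compound 2 by ethoxy in place of hydrogen on an aromatic carbon. Among the compounds with values here, no measured step touches this aromatic ring, so nothing seen bears directly on the change. For compound 3 the expectation is therefore a step no larger than the scatter, no change at the digits printed from compound 2 to compound 3 (within the scatter). Compound 3 is estimated at 7 nM, with a range from 2 nM to 30 nM.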

Compound 3, inhibition constant: 3 nM
Beside the measured number, compound 3's estimate is 2.3-fold (0.37 log units) above it; the range from low to high includes it.
By their numbers in this assay, from the lowest: compound 3; then compound 2; then compound 1.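

Going by these compounds alone, this is the first look at the aromatic ring: in this assay, ethoxy in place of hydrogen, on the carbon para to a large group, brings a modest gain (a 2.3-fold lower number from compound 2 to compound 3 (0.37 log units; beyond the scatter)). This position therefore accepts a group of 3 heavy atoms with no ring, and binding strength does not suffer. Nothing available explains the gain.

As far as these compounds go, it remains open whether methoxy, a longer propoxy chain or an amine at this carbon would do the same. Also open, from the compounds shown here alone, is whether ethoxy would bring a similar gain with cyclopentyl on the amine nitrogen in place of oxan-4-yl.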